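The source may hold more compounds than are shown below. What is called first, only, known or untested is meant among the compounds shown, and "the series" means these compounds.

Compound 1 `COC1=NOC2(CCC[N+](C)(C)C2)C1`: 94000 nM
Compound 2 `BrC1=NOC2(C1)CN1CCC2C1`: 5000 nM

In an assay on cell membranes for displacement of a labelled ligand from Neuronal acetylcholine receptor; alpha4/beta2 (Rattus norvegicus) (on this read-out lower numbers stand for stronger inhibition and higher numbers for weaker inhibition), compound 2 gives 5000 nM, the lower of the two numbers; compound 1 gives 94000 nM, a gap that lies beyond the usual scatter. Compound 3 `COC1=NOC2(C1)CN1CCC2C1` is not yet measured. It differs from compound 2 by methoxy in place of bromo on a carbon with a double bond to nitrogen. Going by the values given here, no measured pair shows this exact exchange on this core; compound 1 also carries a methoxy group, but on a different core, so it offers no direct guide. A moderate weakening is expected, as the step of a 3.0-fold higher number from compound 2 to compound 3 (0.48 log units; beyond the scatter) in this assay. Compound 3 is therefore estimated at 15000 nM, within a range from 3000 nM to 80000 nM.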

Compound 3, inhibition constant: 16000 nM
Beside the measured number, compound 3's estimate is 1.1-fold (0.03 log units) below it; measured number inside the range.
By their numbers in this assay, from the lowest: compound 2; then compound 3; then compound 1.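

Going by these compounds alone, on the shared core, this is the first direct reading of the exchange at this position: in this assay, methoxy in place of bromo gives a 3.2-fold higher number from compound 2 to compound 3 (0.51 log units; beyond the scatter), a modest change that lies beyond the scatter. Compound 1 also carries methoxy, but its core differs, so it could not isolate this change. Nothing measured here explains the step. Going by these compounds, whether an amine or an ethoxy group at this carbon would give a lower or higher number remains open. So does the effect of bromo on the core of compound 1.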